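The source may report more compounds than this note shows. Statements on the series, on what has been measured and on what is new or still open speak of the compounds shown alone.

Measured compounds
- compound 1, `CCCCOc1c(OC)c(OC)cc2c1C(=O)[C@]1(OC)C=C[C@H]2N(C(=O)OC)N1C(=O)OC`: > 300 ug/mL in an ADME assay on KB cells (Homo sapiens) for cytotoxicity; on this read-out lower numbers stand for an effect already at smaller amounts and higher numbers for an effect only at larger amounts of compound
- compound 2, `CCOC(=O)N1[C@@H]2C=C[C@@](OC)(C(=O)c3c2cc(OC)c(OC)c3OCc2ccc(OC)cc2)N1C(=O)OCC`: 63.1 ug/mL in this assay

Compound 1 gives only a limit in this assay, > 300 ug/mL, not a number. Among the measured compounds shown here, compound 2 gives the only number in the set, 63.1 ug/mL. For the measured compounds named here, the one further value shown, that of compound 1, is a limit: the limit of > 300 ug/mL in this assay, at which 1 of the 2 values shown sits. Going by the values given here, no step between two measured compounds is available. The data therefore hold no measured size for a change in one place on this read-out.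

Compound 3, `CCOC(=O)N1[C@@H]2C=C[C@@](OC)(C(=O)c3c2cc(OC)c(OC)c3OCc2ccccc2F)N1C(=O)OCC`, is not yet measured. It differs from compound 2 in one place: 2-fluorophenyl in place of 4-methoxyphenyl on a saturated chain carbon bound to an oxygen on an aromatic ring. Among the compounds with values here, with no measured step for guidance, the expected step from compound 2 to compound 3 in this assay is a 1.0-fold lower number from compound 2 to compound 3 (0.00 log units; within the scatter), that is, none beyond the usual scatter. For compound 3 the expected value in this assay is therefore 63 ug/mL, with a range from 25 ug/mL to 160 ug/mL.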

Compound 3, concentration for half-maximal effect: 99.7 ug/mL
Estimate against measurement, compound 3: 1.6-fold (0.20 log units) below; the range from low to high includes it.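

Among the compounds shown here, the only measured step concerns this place, on a saturated chain carbon bound to an oxygen on an aromatic ring: in this assay, 2-fluorophenyl in place of 4-methoxyphenyl gives a 1.6-fold higher number from compound 2 to compound 3 (0.20 log units; within the scatter). The read-out therefore does not separate these two groups here, although the 4-methoxyphenyl group counts one hydrogen-bond acceptor and the 2-fluorophenyl group none. Compound 1 remains a limit and not a number, so it adds no size of change: the limit of > 300 ug/mL in this assay, at which 1 of the 3 values shown sits.

On these data alone, whether the read-out also stays within the scatter with an unsubstituted phenyl, an amine or a carboxylic acid on this ring, or a longer alkyl chain in place of the benzyl group remains open. As far as these compounds go, how far the shared core tolerates changes at other places also remains open, since this single step covers only this one place.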